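The source may hold more compounds than are shown below. What is called first, only, known or untested is meant among the compounds shown, and "the series" means these compounds.

Measured so far:
- compound 1, `C=CCOc1ccc(C(=O)Nc2ccccn2)cc1`: 19300 nM
- compound 2, `CCCCNc1cccc(NC(=O)c2ccc(OCCC)cc2)n1`: 54100 nM

Both values come from an in vitro assay on HEK-tsA201 cells for antagonist activity at Neuronal acetylcholine receptor; alpha4/beta2 (Homo sapiens), read by fluorescence and calcium flux; a lower number here means a stronger inhibitor, a higher number a weaker inhibitor. Compound 2 stands at the higher of the two numbers, with compound 1 giving the lower one; the gap between them lies beyond the usual scatter of this assay, so compound 2 is the weaker inhibitor of the two. Because the two structures differ in more than one place, their values show only where each stands, not what any single change does.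

Compound 3, `CCCOc1ccc(C(=O)Nc2cccc(NCc3ccccc3)n2)cc1`, has not yet been measured in this assay. It differs from compound 2 in one place: phenyl in place of propyl on a saturated chain carbon bound to a nitrogen on an aromatic ring. Among the compounds with values here, no pair of measured compounds shows this change, so there is no measured step on which to rest an expectation for its size or direction. Both known values are weak, and the change is expected to leave compound 3 near compound 2, with the step from compound 2 to compound 3 estimated at a 1.4-fold lower number from compound 2 to compound 3 (0.13 log units; within the scatter), a size within the scatter. Compound 3 is therefore expected to give about 40000 nM, in a range from 10000 nM to 150000 nM.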

Compound 3, half-maximal inhibitory concentration: > 100000 nM
Compound 3: a limit, no number (the forecaster's own chance of this, stated with the estimate: 25%); at least 2.5-fold (0.39 log units) between middle value and limit.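

Replacing butylamino with benzylamino, which puts phenyl in place of propyl on a saturated chain carbon bound to a nitrogen on an aromatic ring, gives in this assay an at least 1.8-fold higher number from compound 2 to compound 3 (0.26 log units; that floor lies within the scatter). Within the data shown here, this is the first direct reading at this position, and it shows no gain in inhibition from bringing in the aromatic ring, although the floor of the step is too small to establish a real loss on its own. For compound 3 the reading is a limit of the assay and not a number, so the step has a floor but no measured size: the limit of > 100000 nM in this assay, at which 1 of the 3 values shown sits.

Going by these compounds, how far compound 3 truly lies from compound 2 remains open, as does whether any group at this position can give a stronger inhibitor, since a single change in one direction says little about the position as a whole. A shorter chain such as ethyl, a longer chain such as hexyl, or a butyl chain ending in an amine or a carboxylic acid could each answer that, and the compounds shown give no reading for any of them.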